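Methoxy for nitro on the anilino ring: expected effect

The source may hold more compounds than are shown below. What is called first, only, known or untested is meant among the compounds shown, and "the series" means these compounds.

Measured so far:
compound 1, `C#CCSc1nc(Nc2ccccc2)c2ccncc2n1` — in a functional assay on MGC-803 cells (Homo sapiens) for inhibition, read by MTT assay, with a stated time of 72 h (on this read-out higher numbers stand for weaker inhibition and lower numbers for stronger inhibition), compound 1 gives 16200 nM
compound 2, `C#CCSc1nc(Nc2ccc([N+](=O)[O-])cc2)c2ccncc2n1` — in this assay compound 2 gives > 80000 nM, a limit of the assay

Compound 2 stands at the top of the numbers shown: its value is a limit, not a number, as noted under (the limit of > 80000 nM in this assay, at which 1 of the 2 values shown sits), so its true position is open-ended. For the measured compounds named here, the only measured step is an at least 4.9-fold higher number from compound 1 to compound 2 (0.69 log units; beyond the scatter), which itself rests on that limit.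

Compound 3, `C#CCSc1nc(Nc2ccc(OC)cc2)c2ccncc2n1`, differs from compound 2 by methoxy in place of nitro on an aromatic carbon. Going by the values given here, the one step that bears on this change, from compound 1 to compound 2, is bounded on one side only, and methoxy is not hydrogen, so it gives a direction rather than a size. Taking nitro away is expected to bring the number back down toward that of compound 1, with the step from compound 2 to compound 3 estimated at an at least 3.2-fold lower number from compound 2 to compound 3 (0.50 log units; beyond the scatter). Compound 3 is therefore expected to give about 25000 nM in this assay, within a range of 8000 nM to 80000 nM, with a fair chance that only a limit is reported again.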

Compound 3, half-maximal inhibitory concentration: > 80000 nM
Compound 3 was reported as a limit; the forecaster's own chance of this, stated with the estimate: 25%; middle value at least 3.2-fold (0.50 log units) from the limit.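

In this assay, methoxy on this carbon of the anilino ring gives an at least 4.9-fold higher number from compound 1 to compound 3 (0.69 log units; beyond the scatter), so the loss seen with an at least 4.9-fold higher number from compound 1 to compound 2 (0.69 log units; beyond the scatter) is not confined to nitro: both groups tried at this place go with a weaker result than hydrogen. Both steps are bounded on one side only, and compound 1 remains the only one of the three with a measured number, so neither step has a known size. The step between the nitro and methoxy compounds cannot be read, because both values are limits: the limit of > 80000 nM in this assay, at which 2 of the 3 values shown sit.

On these data alone, how far compound 2 and compound 3 lie past that limit remains open, and with it whether nitro and methoxy differ at all at this place. Also open, as far as these compounds go, is whether any group on this carbon goes with the loss or only these two, for example whether fluorine or an amine at the same place would give a number close to compound 1 at 16200 nM.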